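Adding trifluoromethyl to the most soluble compound so far

The source may hold more compounds than are shown below. What is called first, only, known or untested is meant among the compounds shown, and "the series" means these compounds.

- Compound 1 `COc1ccc(O)c(C(=O)Nc2ccc([N+](=O)[O-])cc2Cl)c1`: 2.1 ug/mL
- Compound 2 `O=C(Nc1ccccc1Cl)c1cc(Cl)ccc1O`: 5 ug/mL
- Compound 3 `CC(C)c1cnc(NC(=O)c2cc(Cl)ccc2O)s1`: 1 ug/mL

In a physicochemical assay for solubility (a higher number here means a more soluble compound, a lower number a less soluble compound), compound 2 has the highest of the three numbers (5 ug/mL). Both gaps lie beyond the usual scatter of repeat measurements: compound 1 sits lower (2.1 ug/mL) and compound 3 lower still (1 ug/mL).

The next compound to be tested, compound 4 `O=C(Nc1ccc(C(F)(F)F)cc1Cl)c1cc(Cl)ccc1O`, differs from compound 2 in a single place: trifluoromethyl in place of hydrogen on an aromatic carbon. This is trifluoromethyl in place of hydrogen on an aromatic carbon, meta to a chloro group and para to a large group.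

A comparison with one change is the cleanest kind, since any shift in the number can be tied to that change. Within the data shown here, none of the measured compounds forms such a pair, so the data hold no direct measure of this step. Among the measured compounds shown here, the only guide is weak: compound 1 (2.1 ug/mL) and compound 3 (1 ug/mL) differ from compound 2 in several places, and both read lower.

A fall beyond the scatter is therefore expected in this assay, with an estimated step of a 3.3-fold lower number from compound 2 to compound 4 (0.52 log units; beyond the scatter) for now. Compound 4 is estimated at 1.5 ug/mL (expected range 0.5 ug/mL to 4 ug/mL) once measured.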

Compound 4, solubility: < 1 ug/mL
Compound 4 gave a limit, no number; the forecaster's own chance of this, stated with the estimate: 10%; at least 1.5-fold (0.17 log units) between middle value and limit.
By their numbers in this assay, from the lowest: compound 3; then compound 1; then compound 2.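

In this assay, among these compounds, the step of an at least 5.0-fold lower number from compound 2 to compound 4 (0.69 log units; beyond the scatter) is the first direct measure of trifluoromethyl in place of hydrogen on this aromatic carbon, meta to a chloro group and para to a large group, as compounds 1 and 3 each differ from compound 2 in several places and could only hint at it. Compound 4 reads < 1 ug/mL, which is a limit of the assay and not a number. On these data alone, the step therefore gives only the smallest size the change can have, and its full size stays unknown because the reading stops at a limit: the limit of < 1 ug/mL in this assay, at which 1 of the 4 values shown sits.

The compounds shown give only this one replacement at this one position, so they leave open how a different group on the same aromatic carbon, such as an amine or a carboxylic acid, would compare with compound 2. They also leave open whether trifluoromethyl on another carbon of this ring would give a step of similar size, or whether the number depends on this particular place.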